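The source may report more compounds than this note shows. Statements on the series, on what has been measured and on what is new or still open speak of the compounds shown alone.

Three compounds have been measured in a functional assay on K562 cells (Homo sapiens) for cytotoxicity, read by MTT assay, with a stated time of 24 h; a higher number here means a weaker inhibitor, a lower number a stronger inhibitor:

compound 1, `COc1cc(/C=C2\CN(C)C/C(=C\c3ccccc3F)C2=O)cc(OC)c1`, 6320 nM
compound 2, `CN1C/C(=C\c2ccc(C#N)cc2)C(=O)/C(=C/c2ccccc2F)C1`, 2670 nM
compound 3, `COc1cc(/C=C2\CN(C)C/C(=C\c3ccc(F)cc3)C2=O)cc(OC)c1`, 11300 nM

Compound 1 and compound 3 share a core and differ in one place: 4-fluorophenyl in place of 2-fluorophenyl on a double-bonded chain carbon bound to a double-bonded ring carbon. This change gave a 1.8-fold higher number from compound 1 to compound 3 (0.25 log units; within the scatter) in this assay. Compound 2 has a different core from compound 1; the difference between the two cores is not broken down here. In this assay compound 2 gives the lowest number of the three, and its gap to compound 1 and to compound 3 lies beyond the usual scatter.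

Compound 4, `CN1C/C(=C\c2ccc(F)cc2)C(=O)/C(=C/c2ccc(C#N)cc2)C1`, has not yet been measured in this assay. It stands to compound 2 as compound 3 stands to compound 1: 4-fluorophenyl in place of 2-fluorophenyl on a double-bonded chain carbon bound to a double-bonded ring carbon. The place of the change is the same in both pairs, so it is the same change. Because the earlier step was a 1.8-fold higher number from compound 1 to compound 3 (0.25 log units; within the scatter), a step of similar size is expected from compound 2 to compound 4, namely a 1.8-fold higher number from compound 2 to compound 4 (0.25 log units; within the scatter). On that basis compound 4 is estimated at 4800 nM in this assay, with a likely range from 2000 nM to 12000 nM.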

Compound 4, half-maximal inhibitory concentration: 11300 nM
Estimate against measurement, compound 4: 2.4-fold (0.37 log units) below, and the stated range covers the measured number.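

On the core of compound 2, 4-fluorophenyl in place of 2-fluorophenyl gave a 4.2-fold higher number from compound 2 to compound 4 (0.63 log units; beyond the scatter) in this assay, a step beyond the scatter and modest in size. Set beside the earlier step on the core of compound 1, it does not stand apart, so as far as these two pairs can tell, the change carried from one core to the other: the same change on two cores in this assay, a 1.8-fold higher number (0.25 log units; within the scatter) from compound 1 to compound 3 and a 4.2-fold higher number (0.63 log units; beyond the scatter) from compound 2 to compound 4, 2.4-fold (0.37 log units) apart, within the scatter of two such steps. For the compounds shown here, this does not establish a fixed step size for the series, as it rests on only two pairs, only one step lies beyond the scatter by itself, and neither pair says why the fluorine's place matters.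

On these data alone, whether the step holds when a plain phenyl or a chlorophenyl group stands in place of the fluorophenyl remains open. The compounds shown also leave open what happens to it when a benzyl group replaces the methyl on the ring nitrogen.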